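Fused-core amides against colon cancer cells: a halogen swap

The compounds below may be only part of what the source reports. "The series", "measured", "known", "first", "only" and "open" are said of these compounds alone.

Of the compounds shown here, two of a shared core have been tested in a functional assay on HT-29 cells (Homo sapiens) for antiproliferative activity, read by MTT assay, with a stated time of 72 h; a lower number here means a stronger inhibitor, a higher number a weaker inhibitor. Compound 1 `Cn1ccc2c(Oc3ccc(NC(=O)c4cc5cccnc5n(-c5ccc(F)cc5)c4=O)cc3)ccnc21` gives 250 nM there. Compound 2 `Cn1ccc2c(Oc3ccc(NC(=O)c4cc5cccnc5n(-c5ccc(F)cc5)c4=O)cc3F)ccnc21` carries an extra fluorine on the ring that holds the amide nitrogen and gives 160 nM; the change from compound 1 is a 1.6-fold lower number from compound 1 to compound 2 (0.19 log units; within the scatter), so the two numbers are indistinguishable within the scatter. Compound 2 therefore stands at the lower of the two numbers, but not meaningfully apart from compound 1.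

Compound 3 `Cn1ccc2c(Oc3ccc(NC(=O)c4cc5cccnc5n(-c5ccc(Br)cc5F)c4=O)cc3F)ccnc21` has not yet been measured. It differs from compound 2 in one place: 4-bromo-2-fluorophenyl in place of 4-fluorophenyl on an aromatic nitrogen. Among the compounds with values here, the only step in hand, from compound 1 to compound 2, concerns a different ring and was within the scatter, so it bears only loosely on this new change; there is no measured step for a bromine entering or for a second halogen on the ring attached to the aromatic nitrogen. The expectation is therefore a step of no change at the digits printed from compound 2 to compound 3 (within the scatter) in this assay, with no confident direction. Compound 3 is estimated at 160 nM, within a range of 55 nM to 450 nM.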

Compound 3, half-maximal inhibitory concentration: 3290 nM
Compound 3: the middle estimate sits 21-fold (1.31 log units) below what was measured; measured number outside the range, above it.
By their numbers in this assay, from the lowest: compounds 2 and 1 (each within the scatter of the next); then compound 3.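

The ring on the aromatic nitrogen proves far more sensitive in this assay than the ring holding the amide nitrogen: 4-bromo-2-fluorophenyl in place of 4-fluorophenyl gives a 21-fold higher number from compound 2 to compound 3 (1.31 log units; beyond the scatter), a step well beyond the scatter, whereas the earlier fluorine gave only a 1.6-fold lower number from compound 1 to compound 2 (0.19 log units; within the scatter), which lies within it. So, in this series, a halogen change at this position is not a neutral swap, and the single step from the other ring gave no warning of that. Nothing measured here bears on why the number rises so sharply.

The new group differs from the old one in two ways at once, since it gains a bromine and its halogens sit in a different pattern, so the compounds shown cannot divide the step between those two changes; a 4-bromophenyl or a 2,4-difluorophenyl group on the same nitrogen would be needed to separate them. Also open, going by these compounds, is how this position would respond to a ring carrying an amine or a carboxylic acid, or to a plain alkyl chain in place of the ring, in this assay.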